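A second methoxy on compound 2

The source may hold more compounds than are shown below. What is called first, only, known or untested is meant among the compounds shown, and "the series" means these compounds.

- compound 1 `COc1cc(C(=O)c2sc3ccccc3c2-c2ccccc2)cc(OC)c1OC`: 1900 nM
- compound 2 `COc1ccc(-c2c(C(=O)c3cc(OC)c(OC)c(OC)c3)sc3ccccc23)cc1`: 4200 nM
- compound 3 `COc1ccc(-c2c(C(=O)c3cc(OC)c(OC)c(OC)c3)sc3ccccc23)c(OC)c1`: not yet measured

For the measured compounds named here, in a functional assay on HeLa cells (Homo sapiens) for antiproliferative activity, read by MTT assay, with a stated time of 72 h (a lower number here means a stronger inhibitor, a higher number a weaker inhibitor), compound 2 gives 4200 nM and holds the higher of the two numbers so far, while compound 1 gives 1900 nM and is its only neighbour. The change to compound 3 is methoxy in place of hydrogen on an aromatic carbon, ortho to a large group and meta to a methoxy group, which takes 4-methoxyphenyl to 2,4-dimethoxyphenyl.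

Going by the values given here, only one measured step bears on this change. The same kind of replacement gave a 2.2-fold higher number from compound 1 to compound 2 (0.34 log units; beyond the scatter) and was modest in size. A single step is thin evidence, so the expectation is loose. A further modest step towards a higher number is expected in this assay, although a result within the scatter of compound 2 would not be surprising. This expectation amounts to an estimated 1.4-fold higher number from compound 2 to compound 3 (0.15 log units; within the scatter) and no more.

For compound 3 the expected value is 6000 nM, with an estimated range from 2500 nM to 14000 nM.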

Compound 3, half-maximal inhibitory concentration: 3900 nM
Beside the measured number, compound 3's estimate is 1.5-fold (0.19 log units) above it, within the range that was stated.
By their numbers in this assay, from the lowest: compound 1; then compounds 3 and 2 (each within the scatter of the next).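

In this assay the second methoxy gives a 1.1-fold lower number from compound 2 to compound 3 (0.03 log units; within the scatter) and stays inside the scatter, whereas the first methoxy gave a 2.2-fold higher number from compound 1 to compound 2 (0.34 log units; beyond the scatter) and lay beyond it. The position ortho to a large group and meta to a methoxy group thus accepts a methoxy with no change that can be read from these numbers, so the effect of adding methoxy to this ring is not the same at every step. Seen from the unsubstituted phenyl, 2,4-dimethoxyphenyl in place of phenyl reads a 2.1-fold higher number from compound 1 to compound 3 (0.31 log units; beyond the scatter) and is modest, so compound 2 and compound 3 both stand beyond the scatter from compound 1, which remains the lowest at 1900 nM in this assay.

As far as these compounds go, it remains open whether this position would accept something other than methoxy, such as an amine, a hydroxyl or a longer chain like ethoxy, in the same way. From the compounds shown here alone, it is also open whether any group on this ring could bring the number below that of compound 1. No evidence is given here that would explain this result.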